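Aromatic substituent change from compound 3 to compound 4

A few compounds are considered here, and "the series" means these few. Any claim that something is new, unique, unknown or untested is made for them only; others in the source may bear on it.

Measured so far:
compound 1 `CC[C@@H]1/C=C(\C)C[C@H](C)C[C@H](OC)[C@H]2O[C@@](O)(C(=O)C(=O)N3CCCC[C@H]3C(=O)O[C@H](/C(C)=C/[C@@H]3CC[C@@H](O)[C@H](Oc4ccc(O)cc4)C3)[C@H](C)[C@@H](O)CC1=O)[C@H](C)C[C@@H]2OC` — 0.9 nM in a functional assay on cells for inhibition, with Murine T-cell line (Mus musculus) as the target; on this read-out lower numbers stand for stronger inhibition and higher numbers for weaker inhibition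
compound 2 `CC[C@@H]1/C=C(\C)C[C@H](C)C[C@H](OC)[C@H]2O[C@@](O)(C(=O)C(=O)N3CCCC[C@H]3C(=O)O[C@H](/C(C)=C/[C@@H]3CC[C@@H](Oc4ccc(C(F)(F)F)cc4)[C@H](OC)C3)[C@H](C)[C@@H](O)CC1=O)[C@H](C)C[C@@H]2OC` — 35.8 nM in this assay
compound 3 `CC[C@@H]1/C=C(\C)C[C@H](C)C[C@H](OC)[C@H]2O[C@@](O)(C(=O)C(=O)N3CCCC[C@H]3C(=O)O[C@H](/C(C)=C/[C@@H]3CC[C@@H](Oc4ccc(F)cc4)[C@H](OC)C3)[C@H](C)[C@@H](O)CC1=O)[C@H](C)C[C@@H]2OC` — 3.4 nM in this assay

Compound 3 stands second highest of the three numbers: compound 1 sits lower, beyond the scatter, and compound 2 higher, beyond the scatter, as an 11-fold lower number from compound 2 to compound 3 (1.02 log units; beyond the scatter) shows.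

Compound 4 `CC[C@@H]1/C=C(\C)C[C@H](C)C[C@H](OC)[C@H]2O[C@@](O)(C(=O)C(=O)N3CCCC[C@H]3C(=O)O[C@H](/C(C)=C/[C@@H]3CC[C@@H](Oc4ccc(OC)cc4)[C@H](OC)C3)[C@H](C)[C@@H](O)CC1=O)[C@H](C)C[C@@H]2OC` differs from compound 3 by methoxy in place of fluoro on an aromatic carbon. Going by the values given here, the only measured step at this position, an 11-fold lower number from compound 2 to compound 3 (1.02 log units; beyond the scatter), was large, so the group here matters. Compound 1, carrying hydroxy at the same aromatic carbon but differing elsewhere as well, gives 0.9 nM, which suggests a small substituent is tolerated. For compound 4 a step no larger than the scatter is expected in this assay, a 1.4-fold lower number from compound 3 to compound 4 (0.13 log units; within the scatter). Compound 4 is estimated at 2.5 nM, range 0.8 nM to 8 nM.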

Compound 4, half-maximal inhibitory concentration: 1.4 nM
Beside the measured number, compound 4's estimate is 1.8-fold (0.25 log units) above it; low and high end bracket the measured number.
By their numbers in this assay, from the lowest: compounds 1 and 4 (each within the scatter of the next); then compound 3; then compound 2.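

At this aromatic carbon the read-out in this assay separates even the two smaller groups: methoxy in place of fluoro gives a 2.4-fold lower number from compound 3 to compound 4 (0.39 log units; beyond the scatter), so the position still responds once trifluoromethyl is gone. Methoxy in place of trifluoromethyl gives a 26-fold lower number from compound 2 to compound 4 (1.41 log units; beyond the scatter), the widest step at this position, and the numbers rise in the order methoxy, fluoro, trifluoromethyl across these three compounds. Nothing shown gives a reason for this order. Open, on these data alone, is how an amine, a carboxylic acid or a longer alkoxy chain at this carbon would compare with methoxy on the same core.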